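Trimming the Urea Chain on a Cyanoaziridine Core

The source may report more compounds than this note shows. Statements on the series, on what has been measured and on what is new or still open speak of the compounds shown alone.

Measured in a functional assay on L1210 cells (Mus musculus) for inhibition, read by MTT assay; a higher number here means a weaker inhibitor, a lower number a stronger inhibitor:
Compound 1, `CCCCNC(=O)N1CC1C#N`, gives 12000 nM.
Compound 2, `N#CC1CN1C(=O)Nc1ccc(C(F)(F)F)cc1`, gives 7800 nM.
Compound 3, `CC(=O)c1cccc(NC(=O)N2CC2C#N)c1`, gives 9600 nM.

Of the three, compound 1 carries the highest number, but its gap to compound 3 and its gap to compound 2 both lie within the scatter, so these three cannot be ranked on the data at hand. Compound 4, `CNC(=O)N1CC1C#N`, has not yet been measured. It differs from compound 1 by hydrogen in place of propyl on a saturated chain carbon bound to an amide-type nitrogen. Within the data shown here, no measured pair shows this particular change, so nothing here tells directly how shortening the chain acts in this assay. What the measured set does show is that three compounds with quite different groups on the urea nitrogen land close together, which argues against a large step. The step of a 1.3-fold higher number from compound 1 to compound 4 (0.10 log units; within the scatter) is expected to fall within or only just beyond the scatter, leaning toward a higher number. For compound 4 the expected value in this assay is 15000 nM, with a range from 5000 nM to 45000 nM.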

Compound 4, half-maximal inhibitory concentration: 8700 nM
Estimate against measurement, compound 4: 1.7-fold (0.24 log units) above; the measured number falls inside the stated range.
By their numbers in this assay, from the lowest: compounds 2, 4, 3 and 1 (each within the scatter of the next).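

In this assay, the chain on this urea nitrogen gets its first direct test: hydrogen in place of propyl on a saturated chain carbon bound to an amide-type nitrogen gives a 1.4-fold lower number from compound 1 to compound 4 (0.14 log units; within the scatter) and so leaves butyl and methyl indistinguishable here. Among these compounds, at this position, then, the propyl portion can go without a step beyond the scatter, which the earlier compounds, differing from one another in more than one place, could not show. No measurement shown here bears on the reason for this result.

The compounds shown leave open whether a longer chain than butyl would give a step beyond the scatter. They also leave open whether an amine or a carboxylic acid in place of the butyl chain would do so.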